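The compounds below may be only part of what the source reports. "The series", "measured", "known", "first", "only" and "open" are said of these compounds alone.

Measured compounds in an ADME assay on Raji cells (Homo sapiens) for cytotoxicity, read by CellTiter-Glo and resazurin assay, with a stated time of 72 h; on this read-out higher numbers stand for an effect only at larger amounts of compound and lower numbers for an effect already at smaller amounts:
- compound 1 `CCOC(=O)CCCCCOc1cccc(CNC(C)C)c1`: > 26000 nM
- compound 2 `CCCNCc1cccc(OCCCCCC(=O)OCC)c1`: > 26000 nM

Both entries are limits of the assay rather than numbers. For compound 1 the read-out in this assay is a limit, > 26000 nM. For compound 2 the read-out is likewise a limit, > 26000 nM. Compound 2 therefore stands nowhere in particular on the numbers shown; it merely shares the limit with compound 1. Going by the values given here, the single measured step, a step that the two limits leave unreadable from compound 1 to compound 2, stays unreadable because both values sit at the limit of > 26000 nM in this assay, at which 2 of the 2 values shown sit.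

The next compound, compound 3 `CCOC(=O)CCCCCOc1cccc(C=O)c1`, carries the change (formyl in place of (propylamino)methyl on an aromatic carbon). Among the compounds with values here, no measured step bears on this change, and the one step on record gives no size at all. What is known of compound 2 is only the limit > 26000 nM, so there is no ground to expect a step in this assay beyond the scatter in either direction; the expected step that the limit leaves unreadable from compound 2 to compound 3 is essentially none. Compound 3 is thus estimated at 30000 nM, with a range from 8000 nM to 100000 nM, most likely reported again as a limit.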

Compound 3, half-maximal effective concentration: > 26000 nM
Compound 3: only a limit was reported; the forecaster's own chance of this, stated with the estimate: 70%; the middle value does not contradict the limit.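

In this assay compound 3 gives > 26000 nM as a limit of the assay. The steps linking compound 3 to compound 1 and compound 2 cannot be read, so no new step results: the limit of > 26000 nM in this assay, at which 3 of the 3 values shown sit.

The compounds shown leave open how large any of these changes would be on a measured number in this assay within this series.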